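Benzyl to isobutyl amide change in a cytotoxicity-silent series

This account rests on a few compounds, and the source may have more. Where it says the series, first, only, none or still open, it means among the compounds named here.

Compound 1 `C=CC1=C(C(=O)NCc2ccccc2)C(c2ccc(Cl)c(Cl)c2)OC1` stands at a limit in a functional assay on HeLa cells (Homo sapiens) for cytotoxicity, read by MTT assay, with a stated time of 24 h; on this read-out lower numbers stand for stronger inhibition and higher numbers for weaker inhibition: compound 1 gives > 100000 nM, a limit of the assay rather than a number. Compound 2 `C=CC1=C(C(=O)Nc2ccccc2OC)C(c2ccc(OC)cc2)OC1` likewise gives only a limit, > 100000 nM. Compound 3 `C=CC1=C(C(=O)NCc2ccccc2)C(c2ccc(OC)cc2)OC1` also gives a limit, > 100000 nM. The step that the two limits leave unreadable from compound 1 to compound 3 and the step that the two limits leave unreadable from compound 2 to compound 3 cannot be sized, since (the limit of > 100000 nM in this assay, at which 3 of the 3 values shown sit). Compound 4 `C=CC1=C(C(=O)NCC(C)C)C(c2ccc(Cl)c(Cl)c2)OC1` differs from compound 1 by isopropyl in place of phenyl on a saturated chain carbon bound to an amide-type nitrogen. No measured step covers this change, and none of the shown steps yields a readable size, so no direction beyond the scatter is expected. Compound 4 is expected to stay at the limit, with an estimated 100000 nM between 40000 nM and 300000 nM. The expected step of a number no higher from compound 1 to compound 4 (the limit leaves the size open) is accordingly flat.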

Compound 4, half-maximal inhibitory concentration: 60100 nM
For compound 4 the middle estimate is 1.7-fold (0.22 log units) above the measured one; the range from low to high includes it.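

Isopropyl in place of phenyl on a saturated chain carbon bound to an amide-type nitrogen gives an at least 1.6-fold lower number from compound 1 to compound 4 (0.22 log units; that floor lies within the scatter) in this assay. Compound 4 is thus the only compound shown with a number rather than a limit, so the amide nitrogen substituent is the one place where the series leaves that limit, although the floor of the step stays within the scatter. The other steps cannot be read, and most of the series stays silent: the limit of > 100000 nM in this assay, at which 3 of the 4 values shown sit.

Still open, going by these compounds, is whether a longer chain or a terminal amine in place of isopropyl changes the number. Also open, on these data alone, is whether isobutyl paired with 4-methoxyphenyl, as in compound 3, leaves the limit too.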